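The source may hold more compounds than are shown below. What is called first, only, known or untested is meant among the compounds shown, and "the series" means these compounds.

In a functional assay on WiDr cells (Homo sapiens) for antiproliferative activity, read by sulforhodamine B assay, with a stated time of 48 h (a higher number here means a weaker inhibitor of growth, a lower number a stronger inhibitor of growth), compound 1 `CC(C)(C)[Si](C)(C)O[C@H]1CCCO[C@@H]1CO` gives > 100000 nM, which is a limit of the assay and not a number. Compound 2 `CC(C)(C)[Si](C)(C)O[C@@H]1CCCO[C@@H]1CO` gives > 100000 nM, again only a limit, so its standing is known no more closely than that.

Compound 3 `CC(C)(C)[Si](C)(C)O[C@@H]1CCCO[C@@H]1CO/C=C/CO` is compound 2 with a change at its free hydroxy group: 3-hydroxyprop-1-en-1-yl in place of hydrogen on an oxygen on a saturated carbon. In words, 3-hydroxyprop-1-en-1-yl replaces hydrogen on an oxygen on a saturated carbon.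

Within the data shown here, the only measured step is a step that the two limits leave unreadable from compound 1 to compound 2. It concerns (the fact that compounds 1 and 2 differ only in the configuration as drawn), so it gives no size to carry over to an added group. All the data offer is the limit of > 100000 nM in this assay, at which 2 of the 2 values shown sit.

With no measured sign of growth inhibition to build on, the expected a number no higher from compound 2 to compound 3 (the limit leaves the size open) is small, and another limit is the likeliest report. For compound 3 the estimated value is 100000 nM, with an expected range from 50000 nM to 150000 nM.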

Compound 3, concentration for 50% growth inhibition: > 100000 nM
Compound 3 ended at the assay's limit; the forecaster's own chance of this, stated with the estimate: 75%; the middle value sits exactly at the limit.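

In compound 3 the result is > 100000 nM, which is a limit of the assay and not a number. Compound 2 also stands at a limit, so no step can be read between compound 2 and compound 3. The compounds shown leave open what change, if any, would give a measurable value in this assay.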